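The source may hold more compounds than are shown below. What is called first, only, known or untested is meant among the compounds shown, and "the series" means these compounds.

Measured so far:
Compound 1, `CC(C)C(c1ccc(-c2ccc3cccc(F)c3c2)[nH]c1=O)N1CCCCC1=O`: 40 nM
Compound 2, `CC(C)C(/C=C1\CCNC1=O)c1ccc(-c2ccc3cccc(F)c3c2)[nH]c1=O`: 8.7 nM

Both compounds were tested in a functional assay on CHO cells for antagonist activity at prostaglandin E2 receptor EP3 subtype (Homo sapiens), read by cAMP accumulation; a higher number here means a weaker inhibitor, a lower number a stronger inhibitor. For the measured compounds named here, compound 2 stands at the lowest of the two numbers; the only other compound is compound 1, and the step of a 4.6-fold lower number from compound 1 to compound 2 (0.66 log units; beyond the scatter) separates them. Going by the values given here, that step exchanges one ring group for another at the same saturated chain carbon, and it is the only measured step that bears on what follows.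

Compound 3, `CC(C)C(c1cnc(N)s1)c1ccc(-c2ccc3cccc(F)c3c2)[nH]c1=O`, has not yet been measured in this assay. It differs from compound 2 in one place: a group of 6 heavy atoms (3 carbon, 2 nitrogen, 1 sulfur; one five-membered aromatic ring with 2 hetero atoms) in place of a group of 7 heavy atoms (5 carbon, 1 nitrogen, 1 oxygen; one five-membered non-aromatic ring with 1 hetero atom), on a saturated chain carbon bound to an aromatic carbon and a saturated chain carbon. This is a different kind of exchange from the one already measured, since an aromatic ring with more acceptors now takes the place of the five-membered non-aromatic ring. Among the compounds with values here, with only one measured step as a guide, and that step modest, the expectation for compound 3 is a number close to that of compound 2, with room for a somewhat weaker result. The expected step of a 1.7-fold higher number from compound 2 to compound 3 (0.24 log units; within the scatter) is therefore small. Compound 3 is estimated at 15 nM, within a range of 4 nM to 60 nM.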

Compound 3, half-maximal inhibitory concentration: 39 nM
For compound 3 the middle estimate is 2.6-fold (0.41 log units) below the measured one, and the stated range covers the measured number.
By their numbers in this assay, from the lowest: compound 2; then compounds 3 and 1 (each within the scatter of the next).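

Compound 3 places an aromatic ring, 2-amino-1,3-thiazol-5-yl, on the saturated chain carbon, and in this assay this exchange for the five-membered non-aromatic ring of compound 2 gives a 4.5-fold higher number from compound 2 to compound 3 (0.65 log units; beyond the scatter), so the gain seen with compound 2 does not carry over to this aromatic ring. The other new comparison, a 1.0-fold lower number from compound 1 to compound 3 (0.01 log units; within the scatter), lies within the scatter, so 2-amino-1,3-thiazol-5-yl and 2-oxopiperidin-1-yl, two very different rings, cannot be told apart here, and among these three compounds only compound 2 stands apart from the others. No measurement shown here accounts for the difference between these groups.

As far as these compounds go, how a plain thiazol-5-yl group without the amine, or a simple phenyl group, would read on the same carbon remains open, and this would show whether the amine of compound 3 contributes anything. Also open, from the compounds shown here alone, is whether the lower number of compound 2 belongs to its five-membered ring or to the double bond through which that ring is attached, a question that a 2-oxopyrrolidin-1-yl group on this carbon would help to settle.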